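Tolerance in cell culture: amide-nitrogen substituent change

The compounds below may be only part of what the source reports. "The series", "measured", "known", "first", "only" and "open" are said of these compounds alone.

Measured compounds:
compound 1, `COc1ccc(N2C(=O)/C(=C/c3cc(C)n(-c4cccc(-c5nnn[nH]5)c4)c3C)SC2=S)cc1` — 87000 nM
compound 2, `Cc1cc(/C=C2\SC(=S)N(c3ccc(O)cc3)C2=O)c(C)n1-c1cccc(-c2nnn[nH]2)c1` — 45600 nM

In an ADME assay on MT2 cells (Homo sapiens) for cytotoxicity, read by XTT assay, with a stated time of 4 days (a higher number here means that more compound is tolerated, a lower number that less compound is tolerated), compound 1 gives 87000 nM and compound 2 gives 45600 nM. For the measured compounds named here, the one step between them, a 1.9-fold lower number from compound 1 to compound 2 (0.28 log units; within the scatter), is a change of hydrogen in place of methyl on an oxygen on an aromatic ring. Compound 2 therefore sits within the scatter of compound 1; the two numbers cannot be separated, and neither compound can be called better tolerated than the other.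

Compound 3, `Cc1cc(/C=C2\SC(=S)N(Cc3ccccc3)C2=O)c(C)n1-c1cccc(-c2nnn[nH]2)c1`, is the next compound to be measured. It differs from compound 2 by benzyl in place of 4-hydroxyphenyl on an amide-type nitrogen in a ring. Going by the values given here, no measured step touches the group on the amide-type nitrogen in a ring; the only step in hand concerns the oxygen substituent and lies within the scatter. There is thus nothing in the series that points to a movement in this assay beyond the scatter in either direction, and the working expectation is a number close to that of compound 2. Compound 3 is expected to give 55000 nM in this assay, with a range from 18000 nM to 150000 nM. This estimate means a 1.2-fold higher number from compound 2 to compound 3 (0.08 log units; within the scatter).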

Compound 3, half-maximal cytotoxic concentration: 150000 nM
The estimate for compound 3 lay 2.7-fold (0.44 log units) below the measured number, and the stated range covers the measured number.
By their numbers in this assay, from the lowest: compounds 2, 1 and 3 (each within the scatter of the next, the first and the last beyond it).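

In this assay, for the compounds shown here, the group on the amide-type nitrogen in a ring gives the first step that clears the scatter: a 3.3-fold higher number from compound 2 to compound 3 (0.52 log units; beyond the scatter) for benzyl in place of 4-hydroxyphenyl. Benzyl in place of 4-methoxyphenyl gives a 1.7-fold higher number from compound 1 to compound 3 (0.24 log units; within the scatter) and so cannot be separated, which means that the change at this position is resolved only against the 4-hydroxyphenyl group and not for the swap to benzyl in general. No measurement in hand offers an explanation for the difference between these two steps.

The compounds shown leave open where an unsubstituted phenyl, a longer chain such as phenethyl, or a ring carrying an amine or a carboxylic acid on this same nitrogen would fall relative to the three numbers in hand. Also open, going by these compounds, is whether a benzyl group carrying a hydroxyl on its ring would stand with compound 2 or with compound 3, a comparison that would show whether the step follows the hydroxyl or the benzyl group.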